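Swapping a chlorobutyl chain for a butenyl group on the amide carbonyl

The compounds below may be only part of what the source reports. "The series", "measured", "known", "first", "only" and "open" are said of these compounds alone.

The series shares one core: an amide in which a nitrogen carries a trimethoxyphenyl group and a methoxy-hydroxy-benzyl group. Compound 1 `COc1ccc(CN(C(=O)C2CC2)c2cc(OC)c(OC)c(OC)c2)cc1O` bears a cyclopropyl on the carbonyl carbon and gives 49 nM in a functional assay on HCT-116 cells (Homo sapiens) for inhibition, read by MTT assay, with a stated time of 48 h; on this read-out higher numbers stand for weaker inhibition and lower numbers for stronger inhibition. Going by the values given here, compound 3 `COc1ccc(CN(C(=O)CCCCCl)c2cc(OC)c(OC)c(OC)c2)cc1O` carries a 4-chlorobutyl there and gives 220 nM, the second highest of the three numbers; the one step that touches it, a 4.5-fold higher number from compound 1 to compound 3 (0.65 log units; beyond the scatter), was modest but beyond the scatter. Compound 2 `C/C=C/C(=O)N(Cc1cc(OC)c(OC)c(OC)c1)c1ccc(OC)c(O)c1`, in which the two aryl groups change places around the nitrogen and a propenyl sits on the carbonyl, gives 8450 nM, the highest number shown.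

Compound 4 `CC/C=C/C(=O)N(Cc1ccc(OC)c(O)c1)c1cc(OC)c(OC)c(OC)c1` takes the next step: but-1-en-1-yl in place of 4-chlorobutyl on a carbonyl carbon. Among the compounds with values here, no measured step tests an alkenyl group on this arrangement of the core, so compound 3 itself is the anchor, and compound 2 only shows that an unsaturated acyl on the swapped arrangement reads weakly. A step of a 1.6-fold higher number from compound 3 to compound 4 (0.20 log units; within the scatter) is expected, with compound 4 estimated at 350 nM, between 70 nM and 2000 nM.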

Compound 4, half-maximal inhibitory concentration: 63 nM
Beside the measured number, compound 4's estimate is 5.6-fold (0.74 log units) above it; measured number outside the range, below it.
By their numbers in this assay, from the lowest: compounds 1 and 4 (each within the scatter of the next); then compound 3; then compound 2.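

In this assay, the change on this carbonyl carbon gives a 3.5-fold lower number from compound 3 to compound 4 (0.54 log units; beyond the scatter) and so shows that the acyl group can shift the number with the rest of the structure held fixed. It also shows that an open chain with a double bond need not read weakly on this arrangement of the core, since the comparison with the cyclopropyl group gives a 1.3-fold higher number from compound 1 to compound 4 (0.11 log units; within the scatter) and a ring on the carbonyl carbon is therefore not needed for a number of this order. Nothing measured here accounts for the step from the chlorinated chain.

The step removes the chlorine and adds the double bond at once, leaving open which of the two matters, and a plain butyl group on the carbonyl carbon would separate them. Also open, going by these compounds, is how a longer alkenyl chain, or an amine or carboxylic acid at the chain end, would read in this assay.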